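The source may report more compounds than this note shows. Statements on the series, on what has been measured and on what is new or still open speak of the compounds shown alone.

Three members of this series share one core and differ only in the aryl group at the end of the chain. In a functional assay on MCF7 cells (Homo sapiens) for cytotoxicity (a lower number here means a stronger inhibitor, a higher number a weaker inhibitor), compound 1 `C=C/C=C\[C@H](C)[C@H](OC(N)=O)[C@@H](C)[C@H](O)[C@@H](C)C/C(C)=C\[C@H](C)[C@@H](O)[C@@H](C)/C=C\CCc1cccc(Cl)c1` gives 400 nM, compound 2 `C=C/C=C\[C@H](C)[C@H](OC(N)=O)[C@@H](C)[C@H](O)[C@@H](C)C/C(C)=C\[C@H](C)[C@@H](O)[C@@H](C)/C=C\CCc1cc(F)cc(F)c1` gives 600 nM and compound 3 `C=C/C=C\[C@H](C)[C@H](OC(N)=O)[C@@H](C)[C@H](O)[C@@H](C)C/C(C)=C\[C@H](C)[C@@H](O)[C@@H](C)/C=C\CCc1cccc(OC)c1` gives 330 nM. Compound 3 therefore stands within the scatter of both of the others, as a 1.2-fold lower number from compound 1 to compound 3 (0.08 log units; within the scatter) and a 1.8-fold lower number from compound 2 to compound 3 (0.26 log units; within the scatter) show. The remaining step, a 1.5-fold higher number from compound 1 to compound 2 (0.18 log units; within the scatter), is also within the scatter.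

Compound 4 `C=C/C=C\[C@H](C)[C@H](OC(N)=O)[C@@H](C)[C@H](O)[C@@H](C)C/C(C)=C\[C@H](C)[C@@H](O)[C@@H](C)/C=C\CCc1cc(O)cc(O)c1` has not yet been measured. It differs from compound 3 as follows: 3,5-dihydroxyphenyl in place of 3-methoxyphenyl on a saturated chain carbon, two bonds along the chain from a double-bonded chain carbon. In words, it has 3,5-dihydroxyphenyl in place of 3-methoxyphenyl on a saturated chain carbon, two bonds along the chain from a double-bonded chain carbon.

The three measured steps alter the same aryl group as this change. None of them leaves the scatter. Among the measured compounds shown here, none of the measured compounds carries a 3,5-dihydroxyphenyl group, however, so they offer only indirect guidance and the range must stay wide. No change beyond the scatter is therefore expected, and the estimated step is a 1.5-fold higher number from compound 3 to compound 4 (0.18 log units; within the scatter).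

For compound 4 the estimated value is 500 nM, with an expected range from 150 nM to 1700 nM.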

Compound 4, half-maximal inhibitory concentration: 160 nM
Estimate against measurement, compound 4: 3.1-fold (0.49 log units) above, within the range that was stated.
By their numbers in this assay, from the lowest: compound 4; then compounds 3, 1 and 2 (each within the scatter of the next).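

Among the compounds shown here, at this position, on a saturated chain carbon, two bonds along the chain from a double-bonded chain carbon, the 3,5-dihydroxyphenyl group is the first aryl group to move the number in this assay beyond the scatter, giving a 2.1-fold lower number from compound 3 to compound 4 (0.31 log units; beyond the scatter) and a 2.5-fold lower number from compound 1 to compound 4 (0.40 log units; beyond the scatter) and also a 3.8-fold lower number from compound 2 to compound 4 (0.57 log units; beyond the scatter) in the same direction. The earlier compounds shown here stayed within the scatter of one another, so they gave no sign that this aryl group could matter; compound 4 now stands lowest of the four, although each of its steps is only modest. Nothing measured here accounts for the shift.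

The compounds shown leave open whether both hydroxyl groups are needed, as a single one in 3-hydroxyphenyl or the two methyl ethers in 3,5-dimethoxyphenyl would test. They also leave open whether the lower number is particular to hydroxyl or would also appear with an amine or a carboxylic acid on the ring, as in 3-aminophenyl or 3-carboxyphenyl.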